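Swapping a bicyclic acyl group for phenyl on a thiourea

A few compounds are considered here, and "the series" means these few. Any claim that something is new, unique, unknown or untested is made for them only; others in the source may bear on it.

Of the compounds shown here, two that share a thiourea core have been measured in an ADME assay on BHK cells (Mesocricetus auratus) for cytotoxicity, read by MTT assay, with a stated time of 96 h; on this read-out higher numbers stand for lower toxicity in this test and lower numbers for higher toxicity in this test. Compound 1, `C=C(C)CNC(=S)Nc1cccc(C(F)(F)F)c1`, gives only a limit in this assay, namely > 100000 nM. Compound 2, `O=C(NC(=S)Nc1cccc(C(F)(F)F)c1)[C@H]1C[C@@H]2CC[C@H]1C2`, gives 9600 nM in this assay. This is the only actual number shown. The other value, that of compound 1, is a limit (the limit of > 100000 nM in this assay, at which 1 of the 2 values shown sits). The step considered here goes from compound 2 to compound 3, `O=C(NC(=S)Nc1cccc(C(F)(F)F)c1)c1ccccc1`, which differs from compound 2 in one place: a group of 6 heavy atoms (6 carbon; one six-membered aromatic ring of carbon only) in place of a group of 7 heavy atoms (7 carbon; 2 five-membered non-aromatic rings of carbon only), on a carbonyl carbon. For the measured compounds named here, no measured pair that changes a single group is available, so the direction of this step can only be guessed. Compound 3 is expected to remain close to compound 2 in this assay, with an expected step of a 1.6-fold higher number from compound 2 to compound 3 (0.19 log units; within the scatter) that is not clearly beyond the scatter. Compound 3 is estimated at 15000 nM in this assay, within a range from 4000 nM to 60000 nM.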

Compound 3, half-maximal cytotoxic concentration: > 100000 nM
Compound 3 gave a limit, no number (the forecaster's own chance of this, stated with the estimate: 25%); middle value at least 6.6-fold (0.82 log units) away from the limit.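

In this assay, phenyl in place of the group with 2 five-membered non-aromatic rings of carbon only, on a carbonyl carbon, gives an at least 10-fold higher number from compound 2 to compound 3 (1.01 log units; beyond the scatter), so the read-out at this place does depend on the group it carries. Compound 3 gives only a limit, > 100000 nM, so the step has a lower bound but no exact size. With compound 3, the limit now describes most of this small set: the limit of > 100000 nM in this assay, at which 2 of the 3 values shown sit.

As far as these compounds go, it remains open whether the difference follows the aromatic ring, the ring size or the 3 defined stereocentres that leave with the bicyclic group, since all of these change in this one step. From the compounds shown here alone, it is also open whether a cyclohexyl ring, a pyridine ring or a longer alkyl chain on this carbonyl carbon would give a measurable number or another limit.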